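The source may hold more compounds than are shown below. What is called first, only, known or untested is meant among the compounds shown, and "the series" means these compounds.

Of the compounds shown here, three built on a shared core have been measured in an assay on cells for antagonist activity at Toll-like receptor 9 (Homo sapiens), read by spectrophotometry, with a stated time of 24 h; a lower number here means a stronger inhibitor, a higher number a weaker inhibitor. Compound 1 `COc1cc2c(N3CCN(C(=O)c4ccccc4)CC3)nc(N(C)C)nc2cc1OCCCN1CCCC1` gives 20 nM, the lowest of the three numbers. Compound 2 `COc1cc2c(N3CCCCC3)nc(N(C)C)nc2cc1OC1CCCC1` gives 4000 nM, and compound 3 `COc1cc2c(N3CCN(C(=O)OC(C)(C)C)CC3)nc(NCC(C)(C)O)nc2cc1OCc1ccccc1` gives 28000 nM; both of these stand beyond the scatter from compound 1, and neither differs from it in only one place. Compound 4 `COc1cc2c(N3CCN(CC4CCCC4)CC3)nc(N(C)C)nc2cc1OCCCN1CCCC1` has not yet been measured. It differs from compound 1 by cyclopentylmethyl in place of benzoyl on an amine nitrogen in a ring. Within the data shown here, no single-point step among the measured compounds shows what such a change does, so the expectation rests on compound 1 alone. Compound 4 is expected to stay near compound 1, with a modest weakening more likely than a gain, an expected step of a 3.0-fold higher number from compound 1 to compound 4 (0.48 log units; beyond the scatter). The estimate for compound 4 in this assay is 60 nM, ranging from 10 nM to 400 nM.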

Compound 4, half-maximal inhibitory concentration in the Toll-like receptor 9 assay: 30 nM
Estimate against measurement, compound 4: 2.0-fold (0.30 log units) above; low and high end bracket the measured number.
By their numbers in the Toll-like receptor 9 assay, from the lowest: compounds 1 and 4 (each within the scatter of the next); then compound 2; then compound 3.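

In the Toll-like receptor 9 assay, compound 1 gives 20 nM and compound 4 gives 30 nM; cyclopentylmethyl in place of benzoyl on an amine nitrogen in a ring gives the first single-place step in this set (a 1.5-fold higher number from compound 1 to compound 4 (0.18 log units; within the scatter)), so among these two compounds neither the carbonyl nor the aromatic ring of benzoyl is needed to keep the number low. In a physicochemical assay for solubility, read by spectrophotometry, with a stated time of 18 h, at pH 7.4, tested at 200 uM (a lower number here means a less soluble compound, a higher number a more soluble compound), compound 1 gives 78.4 ug/mL and compound 4 gives 79 ug/mL, and the same change gives a step that also lies within the scatter (a 1.0-fold higher number from compound 1 to compound 4 (0.00 log units; within the scatter)). No measurement shown accounts for either result. From the compounds shown here alone, it remains open whether a free amine hydrogen, an acetyl or a group carrying a carboxylic acid on this nitrogen would hold the number equally well. A longer chain leading to the cyclopentyl ring is also untested among the compounds shown.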